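This account rests on a few compounds, and the source may have more. Where it says the series, first, only, none or still open, it means among the compounds named here.

Compound 1 `COc1cc(-n2cnc3ccc(-c4ccc(C(C)=O)cc4)cc32)cc(OC)c1OC`: 2510 nM
Compound 2 `COc1cc(-n2cnc3ccc(-c4cccc(O)c4)cc32)cc(OC)c1OC`: 250 nM

Among the measured compounds shown here, in a functional assay on A549 cells (Homo sapiens) for antiproliferative activity, read by MTT assay, with a stated time of 72 h (on this read-out lower numbers stand for stronger inhibition and higher numbers for weaker inhibition), compound 2 gives 250 nM, the lower of the two numbers measured so far. The next compound, compound 3 `COc1cc(-n2cnc3ccc(-c4ccc(C)cc4)cc32)cc(OC)c1OC`, has 4-methylphenyl in place of the 3-hydroxyphenyl of compound 2 on an aromatic carbon (4-methylphenyl in place of 3-hydroxyphenyl on an aromatic carbon). For the measured compounds named here, only one measured step bears on this change: a 10-fold lower number from compound 1 to compound 2 (1.00 log units; beyond the scatter), a modest step beyond the scatter, with 3-hydroxyphenyl in place of 4-acetylphenyl. Compound 3 loses the same 3-hydroxyphenyl, and its 4-methylphenyl is closest among the measured groups to the 4-acetylphenyl of compound 1 at 2510 nM. A single step is thin support, but a rise in this assay is expected, probably smaller than the measured one. The expected change is a 4.0-fold higher number from compound 2 to compound 3 (0.60 log units; beyond the scatter). For compound 3 the estimated value is 1000 nM, with an expected range of 300 nM to 3500 nM.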

Compound 3, half-maximal inhibitory concentration: 1940 nM
Compound 3: the middle estimate sits 1.9-fold (0.29 log units) below what was measured, within the range that was stated.
By their numbers in this assay, from the lowest: compound 2; then compounds 3 and 1 (each within the scatter of the next).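

In this assay, replacing 3-hydroxyphenyl with 4-methylphenyl gives a 7.8-fold higher number from compound 2 to compound 3 (0.89 log units; beyond the scatter), a second step beyond the scatter at this position. Methyl in place of acetyl on the same phenyl ring gives a 1.3-fold lower number from compound 1 to compound 3 (0.11 log units; within the scatter), so the 4-methylphenyl and 4-acetylphenyl groups cannot be told apart in this read-out. Among these three compounds, only compound 2, with its 3-hydroxyphenyl, stands apart from the others, although compound 2 differs from compound 3 in both the substituent and where it sits on the ring.

As far as these compounds go, whether the hydroxyl itself or its placement matters remains open, and 4-hydroxyphenyl, 3-methylphenyl or 3-aminophenyl would be needed to separate the two. No supporting measurement is available to account for the difference between compound 2 and the other two compounds.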